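The compounds below may be only part of what the source reports. "The series", "measured", "known", "first", "only" and "open" are said of these compounds alone.

Measured compounds in a functional assay on the whole organism (stomach) for inhibition, with Rattus norvegicus as the target, at a dose of 100 mg/kg by the intraduodenal route; a higher number here means more inhibition at the dose given (going by the name of the read-out), a lower number less inhibition:
- compound 1 `N=C(S)CCCn1nc(-c2ccccc2)ccc1=O`: 75.6%
- compound 2 `N=C(S)CCn1nc(-c2cccs2)ccc1=O`: 50.2%
- compound 3 `N=C(S)CCCCCCN1N=C(c2ccccc2)CCC1=O`: 68.3%

On these numbers compound 1 heads the set of three. The gap to compound 3 lies within the usual scatter of this assay, so the two cannot be told apart on what is shown; the gap to compound 2 lies beyond the scatter. Within the data shown here, no pair of measured compounds differs in only one place, so no measured step is available to calibrate a single change.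

The compound still to be measured is compound 4 `CCOC(=O)CCn1nc(-c2ccccc2)ccc1=O`. Against compound 1 the difference is a group of 5 heavy atoms (3 carbon, 2 oxygen; no ring) in place of a group of 4 heavy atoms (2 carbon, 1 nitrogen, 1 sulfur; no ring), on a saturated chain carbon, two bonds along the chain from an aromatic nitrogen. The group that enters carries no hydrogen-bond donor where the group that leaves carried two, and the chain is not otherwise altered.

Among the measured compounds shown here, since no measured step covers this kind of exchange, the expectation rests on compound 1 alone. The step is expected to be downward and beyond the scatter, with compound 4 estimated to land well under the number of compound 1: a number 30.6 percentage points lower from compound 1 to compound 4 (beyond the scatter). In this assay compound 4 is therefore expected to give about 45%, within a range from 15% to 72%.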

Compound 4, a percentage reported as inhibition, in the whole organism at one dose (the size of the read-out at that dose, not a potency): 6.3%
Compound 4: middle estimate off by 38.7 percentage points, on the high side; the measured number lies below the stated range.
By their numbers in this assay, from the lowest: compound 4; then compound 2; then compounds 3 and 1 (each within the scatter of the next).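

In this assay the series now has its first step that differs in one place: ethoxycarbonyl in place of the group of 4 heavy atoms (2 carbon, 1 nitrogen, 1 sulfur), on a saturated chain carbon, two bonds along the chain from an aromatic nitrogen, gives a number 69.3 percentage points lower from compound 1 to compound 4 (beyond the scatter). The three earlier compounds all carry the same end group, so they could not show how much of the read-out depends on it; with ethoxycarbonyl at this place little inhibition remains at the dose given, as compound 4 gives 6.3%. The entering group has no hydrogen-bond donor where the leaving group had two, but its atoms and acceptors change in the same step, and nothing at hand says what accounts for the size of the fall.

Still open, as far as these compounds go, is whether any replacement of this end group costs as much, which a carboxylic acid, a primary amide or a simple amine at the same place would test. Among these compounds, also open is whether the same exchange has a step of similar size on a longer chain, such as the one in compound 3, or with the thiophene of compound 2.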